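Methylsulfonyl Replaces Ethoxy: Expected Effect on Compound 3

The source may hold more compounds than are shown below. What is called first, only, known or untested is meant among the compounds shown, and "the series" means these compounds.

Compound 1 `CCOc1ccc(NC(=O)Nc2cccc(CNc3nccnc3Cl)c2)cc1` and compound 2 `O=C(Nc1cccc(Cl)c1)Nc1cccc(CNc2nccnc2Cl)c1` share a common core and differ only in the group attached to one amide-type nitrogen. Going by the values given here, in a functional assay on T-24 cells (Homo sapiens) for antiproliferative activity, read by MTT assay, with a stated time of 48 h (a lower number here means a stronger inhibitor, a higher number a weaker inhibitor), compound 1 gives 9080 nM, the highest of the two numbers measured so far, and compound 2 gives 6810 nM. Among the compounds with values here, the only measured step, a 1.3-fold lower number from compound 1 to compound 2 (0.12 log units; within the scatter), shows that exchanging the group on that amide-type nitrogen did not move the number beyond the scatter.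

Compound 3 `CS(=O)(=O)c1ccc(NC(=O)Nc2cccc(CNc3nccnc3Cl)c2)cc1` has not yet been measured. It differs from compound 1 by methylsulfonyl in place of ethoxy on an aromatic carbon. This change touches the same part of the molecule that was altered between compound 1 and compound 2, and that step was small; nothing else measured bears on it. A step of no more than the usual scatter is therefore expected in this assay, in no clear direction. The estimate for compound 3 is 9000 nM, with a range from 3000 nM to 27000 nM. That corresponds to an expected step of a 1.0-fold lower number from compound 1 to compound 3 (0.00 log units; within the scatter).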

Compound 3, half-maximal inhibitory concentration: 29300 nM
Estimate against measurement, compound 3: 3.3-fold (0.51 log units) below; the whole stated range lies below it.
By their numbers in this assay, from the lowest: compounds 2 and 1 (each within the scatter of the next); then compound 3.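

Methylsulfonyl in place of ethoxy gives a 3.2-fold higher number from compound 1 to compound 3 (0.51 log units; beyond the scatter) in this assay and so shows that the group on this aromatic carbon, para to a large group, can change the result. The earlier exchange of the whole 4-ethoxyphenyl group for 3-chlorophenyl gave only a 1.3-fold lower number from compound 1 to compound 2 (0.12 log units; within the scatter) and did not reveal this, while here compound 3 is the weaker inhibitor of the pair, though the step is modest. Nothing measured here explains why this replacement raises the number.

A single replacement at this position leaves open how other groups would behave there. From the compounds shown here alone, whether an amine, a carboxylic acid or a longer chain such as propoxy would stay close to compound 1 or move as far as compound 3 remains unknown.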